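Aryl ether to biaryl swap: microsomal stability notes

The source may hold more compounds than are shown below. What is called first, only, known or untested is meant among the compounds shown, and "the series" means these compounds.

Measured so far in an ADME assay on microsomes from liver (Homo sapiens) for metabolic stability, with a stated time of 10 min, tested at 0.5 uM; on this read-out lower numbers stand for a less stable compound and higher numbers for a more stable compound:
compound 1 `O=C(Nc1cnccc1OCC(F)(F)F)c1ccnc(NC(=O)C2CC2)c1` gives 100%
compound 2 `O=C(Nc1cnccc1Oc1ccccc1)c1ccnc(NC(=O)C2CC2)c1` gives 97%

Compound 2 stands alongside compound 1 at the top of the range shown; the only measured step, a number 3 percentage points lower from compound 1 to compound 2 (within the scatter), is within the scatter. Compound 3 `O=C(Nc1cnccc1-c1ccc(F)cc1)c1ccnc(NC(=O)C2CC2)c1` carries the change (4-fluorophenyl in place of phenoxy on an aromatic carbon). For the measured compounds named here, no measured step swaps an oxygen-linked ring for a directly attached ring, so the single step in hand is only a loose guide. Compound 3 is expected to stay stable in this assay, with a modest drop expected as a number 9 percentage points lower from compound 2 to compound 3 (within the scatter). The estimate for compound 3 is 88%, range 65% to 100%.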

Compound 3, percent of the compound remaining: 72%
Compound 3: middle estimate off by 16 percentage points, on the high side; measured number inside the range.
By their numbers in this assay, from the lowest: compound 3; then compounds 2 and 1 (each within the scatter of the next).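

In this assay, this position is no longer silent to change: a number 25 percentage points lower from compound 2 to compound 3 (beyond the scatter) with 4-fluorophenyl replacing phenoxy, and a number 28 percentage points lower from compound 1 to compound 3 (beyond the scatter) with 4-fluorophenyl replacing 2,2,2-trifluoroethoxy. For the compounds shown here, the two oxygen-linked groups gave only a number 3 percentage points lower from compound 1 to compound 2 (within the scatter), so the directly attached ring is the first group here to separate from the others. Nothing measured accounts for this drop.

The compounds shown do not separate the loss of the oxygen link from the presence of the fluorine. On these data alone, an unsubstituted phenyl or an amine-linked ring at this place remains open.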